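This account rests on a few compounds, and the source may have more. Where it says the series, first, only, none or still open, it means among the compounds named here.

Compound 1 `NC(=O)c1c(NC(=O)c2ccccc2Cl)sc2c1CCN(C(=S)Nc1ccccc1F)C2` gives 12600 nM in a functional assay on MKN-74 cells (Homo sapiens) for antiproliferative activity, with a stated time of 24 h; a higher number here means a weaker inhibitor, a lower number a stronger inhibitor. Compound 2 `NC(=O)c1c(NC(=O)c2ccccc2C(F)(F)F)sc2c1CCN(C(=S)Nc1ccccc1Cl)C2` gives 21900 nM in this assay. Compound 3 `NC(=O)c1c(NC(=O)c2ccccc2Br)sc2c1CCN(C(=S)Nc1ccccc1F)C2` reaches only the limit of > 50000 nM in this assay, so no exact number is known for it. The change from compound 1 to compound 3 is an at least 3.9-fold higher number from compound 1 to compound 3 (0.59 log units; beyond the scatter); because compound 3 sits at the limit of > 50000 nM in this assay, at which 1 of the 3 values shown sits, the step can only be read as a minimum. Compound 4 `NC(=O)c1c(NC(=O)c2ccccc2C(F)(F)F)sc2c1CCN(C(=S)Nc1ccccc1F)C2` differs from compound 3 by trifluoromethyl in place of bromo on an aromatic carbon. Compound 2 carries the same trifluoromethyl group and gives 21900 nM. Since compound 3 stands at the limit, the step to compound 4 is expected to be downward or none. Compound 4 is expected near 30000 nM, between 10000 nM and 60000 nM. The expected step is an at least 1.6-fold lower number from compound 3 to compound 4 (0.22 log units; that floor lies within the scatter).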

Compound 4, half-maximal inhibitory concentration: 19600 nM
Estimate against measurement, compound 4: 1.5-fold (0.18 log units) above, within the range that was stated.
By their numbers in this assay, from the lowest: compounds 1, 4 and 2 (each within the scatter of the next). At a limit, above all of these: compound 3.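

Going from 2-bromophenyl to 2-(trifluoromethyl)phenyl gives an at least 2.5-fold lower number from compound 3 to compound 4 (0.40 log units; beyond the scatter), and this step is only a minimum, since compound 3 sits at a limit: the limit of > 50000 nM in this assay, at which 1 of the 4 values shown sits. At this position, trifluoromethyl and chloro cannot be told apart: a 1.6-fold higher number from compound 1 to compound 4 (0.19 log units; within the scatter). Replacing chloro with fluoro elsewhere in the molecule also makes no readable difference: a 1.1-fold lower number from compound 2 to compound 4 (0.05 log units; within the scatter).

As far as these compounds go, what a methoxy group, an amine or a carboxylic acid would do at this position remains open. The data also do not explain why bromo stands apart from chloro and trifluoromethyl here.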